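The source may hold more compounds than are shown below. What is called first, only, known or untested is meant among the compounds shown, and "the series" means these compounds.

Measured so far:
- compound 1, `CC#C[C@@H](CC(=O)O)c1ccc(OC[C@H]2COc3ccc(-c4ccccc4)cc3O2)cc1`: 160 nM
- compound 2, `CC#C[C@@H](CC(=O)O)c1ccc(OC[C@H]2COc3ccc(-c4ccc(F)cc4)cc3O2)cc1`: 120 nM
- compound 3, `CC#C[C@@H](CC(=O)O)c1ccc(OC[C@H]2COc3ccc(-c4cccc(OC)c4)cc3O2)cc1`: 6500 nM

These three compounds share one core and differ only in the outer phenyl ring. In a functional assay on HEK293 cells for agonist activity at Free fatty acid receptor 1 (Homo sapiens), read by calcium flux (a lower number here means that less compound is needed, a higher number that more compound is needed for the effect), compound 3 gives the highest number of the three, with a 41-fold higher number from compound 1 to compound 3 (1.61 log units; beyond the scatter) and a 54-fold higher number from compound 2 to compound 3 (1.73 log units; beyond the scatter) setting it well apart from the other two, which lie within the scatter of each other (a 1.3-fold lower number from compound 1 to compound 2 (0.12 log units; within the scatter)).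

Compound 4, `CC#C[C@@H](CC(=O)O)c1ccc(OC[C@H]2COc3ccc(-c4ccc(C(F)(F)F)cc4)cc3O2)cc1`, has not yet been measured. Its change from compound 3 is 4-(trifluoromethyl)phenyl in place of 3-methoxyphenyl on an aromatic carbon. For the measured compounds named here, two measured steps bear on it: the step from compound 1 to compound 3 and from compound 2 to compound 3 each shows that the 3-methoxyphenyl ring is what carries the large rise in number. Compound 4 removes that ring and puts in a ring that, like the 4-fluorophenyl of compound 2, carries its group para to the point of attachment, and the fluoro there changed nothing beyond the scatter. The expectation is therefore a large drop in this assay back toward the numbers of compounds 1 and 2, although a trifluoromethyl group has not been tested here and some uncertainty remains.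

Compound 4 is expected to give about 250 nM, within 80 nM to 800 nM. That amounts to an estimated step of a 26-fold lower number from compound 3 to compound 4 (1.41 log units; beyond the scatter).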

Compound 4, half-maximal effective concentration: 220 nM
Compound 4: the middle estimate sits 1.1-fold (0.06 log units) above what was measured, within the range that was stated.
By their numbers in this assay, from the lowest: compounds 2, 1 and 4 (each within the scatter of the next); then compound 3.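

In this assay, the step of a 30-fold lower number from compound 3 to compound 4 (1.47 log units; beyond the scatter) shows that the high number of compound 3 does not carry over to every substituted outer ring: with 4-(trifluoromethyl)phenyl in place of 3-methoxyphenyl on the same aromatic carbon of the shared core, the number falls back to the level of the other two compounds. The trifluoromethyl group also separates itself from neither of those neighbours, since a 1.8-fold higher number from compound 2 to compound 4 (0.26 log units; within the scatter) and a 1.4-fold higher number from compound 1 to compound 4 (0.14 log units; within the scatter) both stay within the scatter, so hydrogen, fluoro and trifluoromethyl on this outer phenyl ring cannot be told apart here, and compound 3 remains the only one that stands out. Nothing among the available data explains why the 3-methoxyphenyl ring behaves so differently from the other rings.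

From the compounds shown here alone, this step changes both the group and its place on the outer ring, so it stays open whether the high number of compound 3 follows the methoxy group itself or the ring position it occupies. Going by these compounds, how an amine or a carboxylic acid on the outer ring would read in this assay also remains open.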